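This account rests on a few compounds, and the source may have more. Where it says the series, first, only, none or still open, it means among the compounds named here.

Compound 1 `Cc1nc2ccc(NC(=O)COc3ccc(OC(F)(F)F)cc3)cn2c1C`: 7.8 nM
Compound 2 `Cc1c(C2CC2)nc2ccc(-n3ccc(OCc4ccccc4)cc3=O)cn12`: 28 nM
Compound 3 `Cc1c(C2CC2)nc2ccc(-n3ccc(OCc4ccc(C(C)C)cc4)cc3=O)cn12`: 240 nM

In an assay on CHO cells for displacement of a labelled ligand from melanin-concentrating hormone receptor 1 (Rattus norvegicus), read by scintillation counting, with a stated time of 1 h (on this read-out higher numbers stand for weaker inhibition and lower numbers for stronger inhibition), compound 3 gives the highest of the three numbers; compound 2 comes nearest to it, and compound 1 lies furthest away. The measured step of an 8.6-fold higher number from compound 2 to compound 3 (0.93 log units; beyond the scatter) is the one that bears on the next change. It is the step that brought the isopropyl group in. Within the data shown here, compound 4 `Cc1c(C2CC2)nc2ccc(-n3ccc(OCc4cncnc4)cc3=O)cn12` differs from compound 3 by pyrimidin-5-yl in place of 4-isopropylphenyl on a saturated chain carbon bound to an oxygen on an aromatic ring, which takes the isopropyl group away again while also exchanging the aromatic ring itself; no measured pair shows what such a ring exchange alone does. Compound 4 is therefore expected to move back toward the number of compound 2, the step of a 4.8-fold lower number from compound 3 to compound 4 (0.68 log units; beyond the scatter) being the expected size. Compound 4 is estimated at 50 nM, between 15 nM and 200 nM.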

Compound 4, half-maximal inhibitory concentration: > 1000 nM
Compound 4: only a limit was reported (the forecaster's own chance of this, stated with the estimate: 3%); at least 20-fold (1.30 log units) between middle value and limit.
By their numbers in this assay, from the lowest: compound 1; then compound 2; then compound 3. At a limit, above all of these: compound 4.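

In this assay compound 4 is known only through a limit: the limit of > 1000 nM in this assay, at which 1 of the 4 values shown sits. Pyrimidin-5-yl in place of 4-isopropylphenyl gives an at least 4.1-fold higher number from compound 3 to compound 4 (0.61 log units; beyond the scatter), so taking the isopropyl group away brought no return toward compound 2. Pyrimidin-5-yl in place of phenyl, on the saturated chain carbon bound to an oxygen on an aromatic ring, gives an at least 35-fold higher number from compound 2 to compound 4 (1.55 log units; beyond the scatter), the first reading of a ring exchange alone at this place.

As far as these compounds go, how far compound 4 lies past its limit remains open. So does whether a pyridin-3-yl group here would stay close to compound 2.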